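The source may report more compounds than this note shows. Statements on the series, on what has been measured and on what is new or still open speak of the compounds shown alone.

Working notes on the series in a functional assay on KYSE-70 cells for antiproliferative activity against KYSE-70 cell line (Homo sapiens), read by MTT assay, with a stated time of 72 h; a higher number here means a weaker inhibitor, a lower number a stronger inhibitor. Compound 1 `O=C(Nc1cccc(F)c1)c1cc(=O)[nH]c2cc(-c3ccccc3)ccc12` gives > 20000 nM. That value is a limit and not a number. Among the compounds with values here, compound 2 `O=C(Nc1cccc(F)c1)c1cc(=O)[nH]c2cc(-c3ccsc3)ccc12`, with thiophen-3-yl in place of phenyl on an aromatic carbon, gives 5100 nM, the only actual number so far in this assay. The measured change is an at least 3.9-fold lower number from compound 1 to compound 2 (0.59 log units; beyond the scatter).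

Compound 3 `O=C(Nc1cccc(F)c1)c1cc(=O)[nH]c2cc(C3=CCOCC3)ccc12` alters the same place on the shared core: a group of 6 heavy atoms (5 carbon, 1 oxygen; one six-membered non-aromatic ring with 1 hetero atom) in place of a group of 5 heavy atoms (4 carbon, 1 sulfur; one five-membered aromatic ring with 1 hetero atom), on an aromatic carbon. Within the data shown here, the incoming group is a six-membered non-aromatic ring with 1 hetero atom, and no measured compound carries such a ring there. Among the measured compounds shown here, only one measured step bears on this change, an at least 3.9-fold lower number from compound 1 to compound 2 (0.59 log units; beyond the scatter), and it shows that the group at this place can move the number beyond the scatter. Its size is open-ended on one side, and it compares two aromatic groups, so it guides the new group only loosely. Compound 3 gives up the thiophen-3-yl group of compound 2, which stands at 5100 nM, so a modest move towards a weaker number is expected. The estimated step is a 2.0-fold higher number from compound 2 to compound 3 (0.29 log units; within the scatter). For compound 3 the estimate is 10000 nM, with an expected range of 3500 nM to 25000 nM.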

Compound 3, half-maximal inhibitory concentration: 10500 nM
Compound 3: middle estimate off by 1.1-fold (0.02 log units), on the low side, within the range that was stated.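

In this assay thiophen-3-yl gives way to a six-membered non-aromatic ring with 1 hetero atom, and a 2.1-fold higher number from compound 2 to compound 3 (0.31 log units; beyond the scatter) is the result. Within the data shown here, this is the first comparison at this position between two actual numbers, and it shows a modest preference for thiophen-3-yl over this ring, although the count of hydrogen-bond acceptors is the same in both groups and the data do not identify what carries the difference. The step from phenyl to the new ring is an at least 1.9-fold lower number from compound 1 to compound 3 (0.27 log units; that floor lies within the scatter) and cannot be read as a real difference between the two groups. Compound 1 remains a limit and not a number: the limit of > 20000 nM in this assay, at which 1 of the 3 values shown sits.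

The compounds shown leave open whether the ring oxygen or the double bond outside aromatic rings matters to the number, a question that a fully saturated tetrahydropyran-4-yl group, or a piperidine ring with an amine nitrogen in place of the oxygen, could address. As far as these compounds go, it also remains open whether the order of compound 2 and compound 3 holds among other five-membered aromatic rings such as furan-3-yl, or with another group on the amide nitrogen.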